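The compounds below may be only part of what the source reports. "The series", "measured", "known", "first", "only" and "open" are said of these compounds alone.

In a functional assay on MDA-MB-231 cells (Homo sapiens) for antiproliferative activity, with a stated time of 72 h (on this read-out lower numbers stand for stronger inhibition and higher numbers for weaker inhibition), compound 1 `CCCC[C@H]1CCCCC[C@@H](C)c2cc(O)c(c(O)c2)[C@@H](CCC)CCCCC[C@@H](C)c2cc(O)c1c(O)c2` gives 1000 nM. Compound 1 lacks a hydroxy that compound 2 `CCC[C@H]1CCCCC[C@@H](C)c2cc(O)c(c(O)c2)[C@@H](CCCCO)CCCCC[C@@H](C)c2cc(O)c1c(O)c2` has, and compound 2 gives 1000 nM, so the two stand level. Compound 3 `C[C@@H]1CCCCC[C@H](CCCCO)c2c(O)cc(cc2O)[C@H](C)CCCCC[C@H](CCCO)c2c(O)cc1cc2O` has not yet been measured. It differs from compound 2 as follows: hydroxy in place of hydrogen on a saturated chain carbon, three bonds along the chain from a saturated ring carbon. Put simply, a propyl chain becomes 3-hydroxypropyl. For the measured compounds named here, only one measured step bears on this change: no change at the digits printed from compound 1 to compound 2 (within the scatter). That step was the same kind of swap, made four bonds along the chain from a saturated ring carbon rather than three. A single step is thin evidence, yet it gives no reason to expect a shift in either direction. The expected step, no change at the digits printed from compound 2 to compound 3 (within the scatter), is therefore none beyond the scatter. The estimate for compound 3 is 1000 nM, with an expected range of 400 nM to 2500 nM.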

Compound 3, half-maximal inhibitory concentration: 1000 nM
Compound 3: the middle estimate sits on the measured number at the digits printed; the range from low to high includes it.
By their numbers in this assay, from the lowest: compounds 1, 2 and 3 (each within the scatter of the next).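

In this assay, changing propyl to 3-hydroxypropyl gives no change at the digits printed from compound 2 to compound 3 (within the scatter). The earlier step, no change at the digits printed from compound 1 to compound 2 (within the scatter), placed a hydroxy four bonds along the chain from a saturated ring carbon, whereas this one shows that a hydroxy three bonds along the chain also leaves the number unmoved, even with the first hydroxy already present. No measurement at hand explains why the read-out stays flat across these two changes.

Since all three compounds stand level, they do not show whether any change on these chains can shift the antiproliferative read-out. An amine or a carboxylic acid in place of the hydroxy, or a longer chain carrying the hydroxy, remains an open question.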